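This account rests on a few compounds, and the source may have more. Where it says the series, first, only, none or still open, it means among the compounds named here.

Measured so far in a functional assay on NCI-H460 cells (Homo sapiens) for cytotoxicity, read by MTT assay, with a stated time of 68 h; a lower number here means a stronger inhibitor, a higher number a weaker inhibitor:

compound 1 `COC(=O)c1ccc(-c2cccc(NC(=O)C(Cl)Cl)c2)cc1`: > 50000 nM, a limit of the assay rather than a number
compound 2 `O=C(Nc1cccc(-c2ccc(Cl)cc2)c1)C(Cl)Cl`: > 50000 nM, likewise a limit of the assay

Compound 2 therefore stands at the limit of > 50000 nM in this assay, at which 2 of the 2 values shown sit, where every value shown so far sits, so neither compound has shown measurable cytotoxicity. Among the measured compounds shown here, the single measured step, a step that the two limits leave unreadable from compound 1 to compound 2, exchanges one small group on an aromatic carbon. Both ends of it are limits, and its size cannot be read.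

Compound 3 `Cc1ccc(-c2cccc(NC(=O)C(Cl)Cl)c2)cc1` differs from compound 2 by methyl in place of chloro on an aromatic carbon. For the measured compounds named here, the one step that bears on this change is a step that the two limits leave unreadable from compound 1 to compound 2, and it gives no readable size, so the only guide is that every value so far sits at the limit of > 50000 nM in this assay, at which 2 of the 2 values shown sit. No movement beyond the scatter is expected in this assay. The step that the limit leaves unreadable from compound 2 to compound 3 is expected to be essentially none because compound 2 already rests at the limit of > 50000 nM in this assay, at which 2 of the 2 values shown sit. Compound 3 is thus estimated at about 60000 nM, with a range from 30000 nM to 150000 nM, most likely reported once more as a limit.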

Compound 3, half-maximal inhibitory concentration: 8000 nM
The estimate for compound 3 lay 7.5-fold (0.88 log units) above the measured number, and the stated range ends above it.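

Among the compounds shown here, this position on the aromatic ring, para to a large group, is the first place where a change gives a measurable response in this assay, and replacing chloro with methyl produces an at least 6.2-fold lower number from compound 2 to compound 3 (0.79 log units; beyond the scatter). Replacing methoxycarbonyl with the same methyl gives a similar result, an at least 6.2-fold lower number from compound 1 to compound 3 (0.79 log units; beyond the scatter), so the measurable activity appears with methyl and with neither of the other two groups, even though chloro and methyl each count as a single heavy atom with no hydrogen-bond donors or acceptors and no net charge. Both steps give only a minimum size, because compound 1 and compound 2 rest at a limit of the assay rather than at a number: the limit of > 50000 nM in this assay, at which 2 of the 3 values shown sit.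

On these data alone, the step between compound 1 and compound 2 cannot be read, so chloro and methoxycarbonyl cannot be ranked against each other, and how far compound 3 truly lies from either remains unknown. As far as these compounds go, with a single measurable compound, it also remains open whether the response is particular to methyl or would persist with a slightly longer chain such as ethyl, or with an oxygen-linked group such as methoxy or a nitrogen-based group such as an amine at this position.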